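A few compounds are considered here, and "the series" means these few. Any claim that something is new, unique, unknown or untested is made for them only; others in the source may bear on it.

Measured so far:
compound 1 `C=CCn1c(=O)/c(=C\c2cccc(Cl)c2Cl)[nH]c(=O)/c1=C\c1ccccc1OC` — 500 nM
compound 2 `C=CCn1c(=O)/c(=C\c2ccc(F)c(Br)c2)[nH]c(=O)/c1=C\c1ccccc1OC` — "not active" (no number reported)

In a functional assay on U-937 cells (Homo sapiens) for cytotoxicity, read by CCK-8 assay, with a stated time of 72 h (a higher number here means a weaker inhibitor, a lower number a stronger inhibitor), compound 1 gives 500 nM. Compound 2 is reported as "not active" (no number reported) with no number given, so compound 2 stands without a value on the scale; the two compounds that share the core differ only in the aryl group on the exocyclic double bond, and one yields a number while the other does not.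

Compound 3 `C=CCn1c(=O)/c(=C\c2cc(F)ccc2C)[nH]c(=O)/c1=C\c1ccccc1OC` has not yet been tested. It differs from compound 2 as follows: 5-fluoro-2-methylphenyl in place of 3-bromo-4-fluorophenyl on a double-bonded chain carbon bound to an aromatic carbon. Within the data shown here, no measured step runs between compound 2 and compound 3, and with compound 2 lacking a number no direction can be read from the data; compound 1 shows only that a different aryl group at this position can give a measurable result.

Compound 3 is therefore estimated to fall at 2500 nM, within 400 nM to 15000 nM, with a real chance of no number at all.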

Compound 3, half-maximal inhibitory concentration: 1000 nM
Beside the measured number, compound 3's estimate is 2.5-fold (0.40 log units) above it, within the range that was stated.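

In this assay, placing 5-fluoro-2-methylphenyl where 2,3-dichlorophenyl stood on a double-bonded chain carbon bound to an aromatic carbon gives a 2.0-fold higher number from compound 1 to compound 3 (0.30 log units; within the scatter) and so leaves the read-out unchanged within the scatter, which shows that a number at this place does not need two chlorines. The step from compound 2 cannot be read since compound 2 has no number, yet with the same count of heavy atoms in the entering group, compound 3 gives 1000 nM in this assay where compound 2 gives none. Nothing measured here accounts for this difference between the aryl groups.

Which part of 3-bromo-4-fluorophenyl sets compound 2 apart from compound 1 and compound 3 remains open. Also open, as far as these compounds go, is whether a phenyl carrying an amine or a carboxylic acid at this place would give a number at all.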